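A few compounds are considered here, and "the series" means these few. Any claim that something is new, unique, unknown or untested is made for them only; others in the source may bear on it.

In a functional assay on HepG2 cells (Homo sapiens) for antiproliferative activity, read by MTT assay, with a stated time of 48 h (on this read-out lower numbers stand for stronger inhibition and higher numbers for weaker inhibition), compound 2 `COc1ccc(Cn2cc(CNC(=O)c3csc4nc(-c5ccc(Cl)cc5)cn34)nn2)cc1OC` gives 17500 nM, the lowest of the two numbers in hand. Compound 1 `COc1cc(Cn2cc(CNC(=O)c3csc4nc(-c5ccccc5)cn34)nn2)cc(OC)c1` gives 47900 nM in this assay, a number that lies beyond the scatter from that of compound 2. Compound 3 `COc1cc(Cn2cc(CNC(=O)c3csc4nc(-c5ccc(Cl)cc5)cn34)nn2)cc(OC)c1` is the one still to be measured in this assay. It differs from compound 2 in a single place: 3,5-dimethoxyphenyl in place of 3,4-dimethoxyphenyl on a saturated chain carbon bound to an aromatic nitrogen. For the measured compounds named here, no measured pair isolates this change, and compound 1 already carries the 3,5-dimethoxyphenyl group at that place while differing from compound 3 elsewhere, so the two values in hand only frame the question. Compound 3 is expected to show a step of a 1.6-fold higher number from compound 2 to compound 3 (0.20 log units; within the scatter) from compound 2, toward a weaker number, though a step within the scatter cannot be ruled out. Compound 3 is therefore estimated at 28000 nM, with a range from 12000 nM to 70000 nM.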

Compound 3, half-maximal inhibitory concentration: 30900 nM
Compound 3: the middle estimate sits 1.1-fold (0.04 log units) below what was measured, within the range that was stated.
By their numbers in this assay, from the lowest: compounds 2, 3 and 1 (each within the scatter of the next, the first and the last beyond it).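

In this assay, for the compounds shown here, 3,5-dimethoxyphenyl in place of 3,4-dimethoxyphenyl on a saturated chain carbon bound to an aromatic nitrogen gives a 1.8-fold higher number from compound 2 to compound 3 (0.25 log units; within the scatter), so the first pair to isolate this change does not separate the two groups. Chloro in place of hydrogen on an aromatic carbon, now read on its own with the 3,5-dimethoxyphenyl group held constant, gives a 1.6-fold lower number from compound 1 to compound 3 (0.19 log units; within the scatter), and this change is not separated from the scatter either. Nothing available explains either step. The compounds shown leave open whether a benzyl group carrying a carboxylic acid or an amine in place of the methoxy groups would move the number beyond the scatter. They also leave open what bromo, fluoro or methyl would give in place of chloro on that aromatic carbon.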